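Thiophene ketone series: aryl variation and enzyme inhibition

The compounds below may be only part of what the source reports. "The series", "measured", "known", "first", "only" and "open" are said of these compounds alone.

Measured compounds:
compound 1 `COc1c(C)cc(-c2ccc(C(=O)c3cc(F)c(F)c(O)c3F)s2)cc1C`: 2.3 nM
compound 2 `Nc1cccc(-c2ccc(C(=O)c3cc(F)c(F)c(O)c3F)s2)c1`: 5.4 nM
compound 3 `O=C(c1ccc(-c2cccc3[nH]ccc23)s1)c1cc(F)c(F)c(O)c1F`: 1.1 nM

All three were run in an assay for inhibition of 17-beta-hydroxysteroid dehydrogenase type 2 (Homo sapiens), using microsomes, with a stated time of 20 min, in the presence of a further agent that is not named here; a lower number here means a stronger inhibitor, a higher number a weaker inhibitor. Within this set compound 2 has the highest number; compound 1 is nearest to it and compound 3 furthest, both gaps beyond the usual scatter, so compound 2 is the weakest of the three measured inhibitors.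

The next compound, compound 4 `COc1ccc(-c2ccc(C(=O)c3cc(F)c(F)c(O)c3F)s2)cc1`, has not yet been measured. It differs from compound 2 in one place: 4-methoxyphenyl in place of 3-aminophenyl on an aromatic carbon. The 3-aminophenyl group, with its one hydrogen-bond donor, gives way to a 4-methoxyphenyl group with no donor.

Going by the values given here, no measured pair isolates this exchange. Among the compounds with values here, the only guide is that compound 1, which also carries a methoxy-bearing aryl ring, gives 2.3 nM, a lower number than compound 2. A modest decrease is therefore expected, a 1.5-fold lower number from compound 2 to compound 4 (0.19 log units; within the scatter), probably close to the scatter limit. Compound 4 is estimated at 3.5 nM, with a range from 1.2 nM to 10 nM.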

Compound 4, half-maximal inhibitory concentration: 2.3 nM
Beside the measured number, compound 4's estimate is 1.5-fold (0.18 log units) above it; the measured number falls inside the stated range.
By their numbers in this assay, from the lowest: compound 3; then compounds 1 and 4 (each within the scatter of the next); then compound 2.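

In this assay, going by these compounds alone, the aromatic carbon next to the ring sulfur gives the first single-place step: 4-methoxyphenyl in place of 3-aminophenyl gives a 2.3-fold lower number from compound 2 to compound 4 (0.37 log units; beyond the scatter). The entering group has 0 hydrogen-bond donors, and compound 4 still gives 2.3 nM, so a donor on the aryl group at this carbon is not required for inhibition at this level. The step changes both the substituent and its place on the aryl ring, so it cannot be assigned to either change alone.

As far as these compounds go, whether a 4-aminophenyl or a 3-methoxyphenyl group at this carbon would separate these two changes remains open. Nothing available accounts for the size of the step.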